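Amide variation and cell toxicity in the shared core series

A few compounds are considered here, and "the series" means these few. Any claim that something is new, unique, unknown or untested is made for them only; others in the source may bear on it.

Measured so far:
compound 1, `COc1ccc2nc(C)cc(OC(C)(C)C(=O)Nc3cc(C)cc(C)c3)c2c1`, > 100000 nM
compound 2, `COc1ccc2nc(C)cc(OCC(=O)NCc3cc(C)cc(C)c3)c2c1`, > 100000 nM

In a toxicity assay on HepG2 cells (Homo sapiens) for inhibition, read by CellTiter-Glo, with a stated time of 48 h (a higher number here means a weaker inhibitor, a lower number a stronger inhibitor), compound 1 reaches only the limit of the assay, > 100000 nM, and no number. In this assay compound 2 likewise gives only a limit, > 100000 nM. So compound 2 stands where everything measured so far stands, on the limit; what holds across the pair is the limit of > 100000 nM in this assay, at which 2 of the 2 values shown sit.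

Compound 3, `COc1ccc2nc(C)cc(OCC(=O)Nc3ccc(Cl)cc3)c2c1`, is the next case. It differs from compound 2 by 4-chlorophenyl in place of 3,5-dimethylbenzyl on an amide-type nitrogen. For the measured compounds named here, no step between two measured compounds is on record, so the size of the change is open; with both measured values sitting on the limit, the expected step that the limit leaves unreadable from compound 2 to compound 3 is none beyond the scatter. Compound 3 is thus expected to sit at about 150000 nM, within a range from 40000 nM to 600000 nM, most likely reported again as a limit.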

Compound 3, half-maximal inhibitory concentration: > 100000 nM
Compound 3 ended at the assay's limit; the forecaster's own chance of this, stated with the estimate: 80%; the middle value is on the limit's open side.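

No step can be read from compound 2 to compound 3, as both values are limits and not numbers: the limit of > 100000 nM in this assay, at which 3 of the 3 values shown sit.

The compounds shown leave open whether any amide on the shared core gives a readable value in this assay, and how these amide groups would rank there.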